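A Ring Swap in a Weakly Cytotoxic Series

This account rests on a few compounds, and the source may have more. Where it says the series, first, only, none or still open, it means among the compounds named here.

Of the compounds shown here, three of one shared core have been measured in a functional assay on Bel-7402 cells (Homo sapiens) for cytotoxicity, read by MTT assay; on this read-out lower numbers stand for stronger inhibition and higher numbers for weaker inhibition. Compound 1 `Cc1nc(Nc2cccc(Cl)c2)sc1C(=O)/C=C/c1ccccc1` reaches only the assay limit of > 25000 nM, which is a limit and not a number. Compound 2 `Cc1ccccc1Nc1nc(C)c(C(=O)/C=C/c2ccc(Cl)cc2)s1` likewise gives only the limit of > 25000 nM. Among the measured compounds shown here, compound 3 `Cc1nc(Nc2ccc(Cl)c(Cl)c2)sc1C(=O)/C=C/c1ccccc1` gives 21500 nM, and this is the single real number among the three, so compound 3 stands as the only compound with a measured value rather than a limit. For the measured compounds named here, the one step between measured compounds, an at least 1.1-fold lower number from compound 1 to compound 3 (0.06 log units; that floor lies within the scatter), rests on the limit described by the limit of > 25000 nM in this assay, at which 2 of the 3 values shown sit, and so lies within the scatter.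

Compound 4 `Cc1ccccc1Nc1nc(C)c(C(=O)/C=C/c2ccccc2)s1` differs from compound 3 by 2-methylphenyl in place of 3,4-dichlorophenyl on a nitrogen on an aromatic ring. Going by the values given here, no measured step covers this exchange directly. Compound 2 carries the same 2-methylphenyl on that nitrogen and reports only a limit. Compound 1, which lacks both chlorines, also reports only a limit. The step of a 1.5-fold higher number from compound 3 to compound 4 (0.17 log units; within the scatter) is therefore expected to run toward weaker inhibition, with a fair chance that compound 4 again returns only a limit. Compound 4 is estimated at 32000 nM, within a range from 15000 nM to 80000 nM.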

Compound 4, half-maximal inhibitory concentration: > 25000 nM
Compound 4: a limit, no number (the forecaster's own chance of this, stated with the estimate: 65%); the middle value is on the limit's open side.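

From the compounds shown here alone, the exchange of 3,4-dichlorophenyl for 2-methylphenyl on a nitrogen on an aromatic ring comes out as an at least 1.1-fold higher number from compound 3 to compound 4 (0.06 log units; that floor lies within the scatter), so in this assay the true size of this step stays unknown beyond that floor. Compound 4, which carries no chlorine at all, returns a limit and not a number: > 25000 nM. The steps to compound 4 from compound 1 and from compound 2 cannot be read, since both ends of each are limits, and the limit now accounts for most of the series: the limit of > 25000 nM in this assay, at which 3 of the 4 values shown sit.

Compound 3 remains the only compound with a measured number, so the compounds shown do not tell whether any group on that nitrogen can bring the value clearly down from the limit. Going by these compounds, whether an amine or a carboxylic acid on the aromatic ring carried by that nitrogen, or a longer chain in place of the methyl of 2-methylphenyl, would give a number that can be compared with that of compound 3 stays open.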